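Adding a double bond to the long ester chain

This account rests on a few compounds, and the source may have more. Where it says the series, first, only, none or still open, it means among the compounds named here.

- compound 1 `CCCCCCCCCCCCCC(=O)OC1=C(CC=C(C)C)C(=O)c2ccccc2C1=O` gives > 100000 nM as a limit of the assay
- compound 2 `CCCCCCCCCCCCCCCCCC(=O)OC1=C(CC=C(C)C)C(=O)c2ccccc2C1=O` gives > 100000 nM as a limit of the assay

Both compounds were tested in a functional assay on U-373MG ATCC cells (Homo sapiens) for inhibition, read by MTT assay (on this read-out lower numbers stand for stronger inhibition and higher numbers for weaker inhibition), and neither returned a real number. Compound 2 stands only at the limit > 100000 nM and this is not a measured potency. Among the compounds with values here, the whole picture so far is the limit of > 100000 nM in this assay, at which 2 of the 2 values shown sit, and no compound has yet given a number.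

Compound 3 `CCCCCCCC/C=C\CCCCCCCC(=O)OC1=C(CC=C(C)C)C(=O)c2ccccc2C1=O` keeps the shared core and changes only the ester chain, as counted here: dec-1-en-1-yl in place of decyl on a saturated chain carbon, seven bonds along the chain from a carbonyl carbon and in words, dec-1-en-1-yl in place of decyl on a saturated chain carbon, seven bonds along the chain from a carbonyl carbon.

Within the data shown here, one measured step bears on this, and it concerns chain length, not a double bond. That step, a step that the two limits leave unreadable from compound 1 to compound 2 and so it gives no size to carry over. With nothing pointing either way, no change beyond the scatter is expected in this assay and another limit is the likeliest report. The expected step is a number no higher from compound 2 to compound 3 (the limit leaves the size open) and it remains an estimate. For compound 3 the estimated value is 100000 nM with an expected range from 40000 nM to 200000 nM in this estimate.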

Compound 3, half-maximal inhibitory concentration: 84000 nM
The estimate for compound 3 lay 1.2-fold (0.08 log units) above the measured number, and the stated range covers the measured number.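

In this assay, within the data shown here, compound 3 gives 84000 nM, the first measured number in this short series, so a change at this place on the chain can bring a reading inside the range of the assay. Putting dec-1-en-1-yl in place of decyl, seven bonds along the chain from a carbonyl carbon, gives an at least 1.1-fold lower number from compound 2 to compound 3 (0.07 log units; that floor lies within the scatter), and the same group in place of hexyl gives an at least 1.1-fold lower number from compound 1 to compound 3 (0.07 log units; that floor lies within the scatter); both are floors rather than true sizes, and each floor lies within the usual scatter, so neither shows on its own that the double bond matters. The step between the two saturated esters cannot be read, and those two compounds stay at a limit: the limit of > 100000 nM in this assay, at which 2 of the 3 values shown sit.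

The compounds shown leave open how large the true step to compound 3 is, and whether any real potency can be reached with this kind of chain at all. They also leave open what a longer chain, a double bond elsewhere along the chain, the other geometry of that double bond, or an amide in place of the ester would give.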